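The source may hold more compounds than are shown below. What is called first, only, known or untested is meant among the compounds shown, and "the series" means these compounds.

Measured so far, in a physicochemical assay for solubility, in phosphate buffer, measured as kinetic solubility, with a stated time of 1 h, at pH 7.4; on this read-out lower numbers stand for lower solubility and higher numbers for higher solubility:

compound 1 `COc1ccc2nc(C)cc(OC(C)(C)C(=O)Nc3cc(C)cc(C)c3)c2c1`: 20000 nM
compound 2 `COc1ccc2nc(C)cc(NCC(=O)Nc3cc(C)cc(C)c3)c2c1`: 204000 nM
compound 3 `COc1ccc2nc(C)cc(OCC(=O)Nc3c(C)cccc3C)c2c1`: 112000 nM

All three compounds share the same core and differ in the linker and in the ring carried on the amide nitrogen. Among the three numbers, compound 3 sits second highest. Its value and that of compound 2 lie within the usual scatter of each other, so nothing can be said about which of the two dissolves better. Compound 1, in contrast, gives a number well below that of compound 3, a gap beyond the scatter.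

Compound 4 `COc1ccc2nc(C)cc(OCC(=O)Nc3ccccn3)c2c1` is not yet measured. It differs from compound 3 in one place: pyridin-2-yl in place of 2,6-dimethylphenyl on an amide-type nitrogen. Going by the values given here, no pair of measured compounds shows this exact change, so the size of the step is not known from the data. The change removes a carbon-only ring and brings in a ring with one hetero atom and one hydrogen-bond acceptor. Compound 4 is expected to show a modest rise in this assay, with a step of a 1.6-fold higher number from compound 3 to compound 4 (0.21 log units; within the scatter) that may well stay close to the scatter. The estimated value of compound 4 is 180000 nM, with a plausible range from 80000 nM to 400000 nM.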

Compound 4, solubility: 29000 nM
Estimate against measurement, compound 4: 6.2-fold (0.79 log units) above, and the stated range ends above it.
By their numbers in this assay, from the lowest: compounds 1 and 4 (each within the scatter of the next); then compounds 3 and 2 (each within the scatter of the next).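

In this assay, pyridin-2-yl in place of 2,6-dimethylphenyl on the amide-type nitrogen gives a 3.9-fold lower number from compound 3 to compound 4 (0.59 log units; beyond the scatter), a step beyond the usual scatter and the first step that can be read among these compounds. It shows that the group at this place can move the number by more than the scatter, and that bringing in a ring with a hetero atom and a hydrogen-bond acceptor does not have to give a higher number. No measurement shown here explains this step.

This single change swaps the ring and removes the methyl groups together, so it remains open which of these lies behind the step. On these data alone, a plain phenyl on the same nitrogen could separate the two, and the effect of an amine or a carboxylic acid on that ring also remains open.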